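A few compounds are considered here, and "the series" means these few. Any claim that something is new, unique, unknown or untested is made for them only; others in the source may bear on it.

Three measured members of the series share one core and differ only in the chain on the amine nitrogen: compound 1 `CCCCCNCc1c(O)ccc2ccc(=O)oc12`, compound 2 `CC(C)CNCc1c(O)ccc2ccc(=O)oc12` and compound 3 `CCNCc1c(O)ccc2ccc(=O)oc12`. In an assay on isolated protein for inhibition of seed linoleate 13S-lipoxygenase-1 (Glycine max) (a higher number here means a weaker inhibitor, a lower number a stronger inhibitor), compound 1 gives 59000 nM, compound 2 gives 47000 nM and compound 3 gives 52000 nM. All three steps among them stay within the scatter: a 1.3-fold lower number from compound 1 to compound 2 (0.10 log units; within the scatter), a 1.1-fold lower number from compound 1 to compound 3 (0.05 log units; within the scatter) and a 1.1-fold higher number from compound 2 to compound 3 (0.04 log units; within the scatter). Compound 3 thus sits with the other two, nearest to compound 2 and furthest from compound 1, without separation beyond the scatter.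

Compound 4 `NCCNCc1c(O)ccc2ccc(=O)oc12` is not yet measured. The change from compound 3 is amino in place of hydrogen on a saturated chain carbon, two bonds along the chain from an amine nitrogen. The step that bears most directly on this place is a 1.1-fold lower number from compound 1 to compound 3 (0.05 log units; within the scatter), where a propyl was removed from the same chain carbon without effect beyond the scatter; the alkyl variations at the carbon bound to the nitrogen, a 1.3-fold lower number from compound 1 to compound 2 (0.10 log units; within the scatter) and a 1.1-fold higher number from compound 2 to compound 3 (0.04 log units; within the scatter), were likewise flat. Among the measured compounds shown here, no measured step introduces an amino group, so the data give no ground for a shift in either direction. For compound 4 in this assay a value of 50000 nM is expected, with a range of 20000 nM to 130000 nM. The expected step is a 1.0-fold lower number from compound 3 to compound 4 (0.02 log units; within the scatter).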

Compound 4, half-maximal inhibitory concentration: >> 1000000 nM
Compound 4: no number, only a limit (the forecaster's own chance of this, stated with the estimate: 10%); at least 20-fold (1.30 log units) between middle value and limit.
By their numbers in this assay, from the lowest: compounds 2, 3 and 1 (each within the scatter of the next). At a limit, above all of these: compound 4.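

In this assay the reading for compound 4 is a limit and not a number: the limit of >> 1000000 nM in this assay, at which 1 of the 4 values shown sits.

The chain on the amine nitrogen, flat so far under alkyl changes, does respond to amino on the saturated chain carbon, two bonds along the chain from an amine nitrogen, with an at least 19-fold higher number from compound 3 to compound 4 (1.28 log units; beyond the scatter), and the other two comparisons agree, with an at least 21-fold higher number from compound 2 to compound 4 (1.32 log units; beyond the scatter) and an at least 16-fold higher number from compound 1 to compound 4 (1.22 log units; beyond the scatter). The tolerance seen among compound 1, compound 2 and compound 3 therefore covers these alkyl chains only and does not extend to the 2-aminoethyl chain.

Open, as far as these compounds go, is whether this step belongs to the amino group itself or would also follow from a hydroxyl or methoxy group at the same carbon. Also open, from the compounds shown here alone, is whether a dimethylamino group, or an amino group carried further out on a longer chain, gives the same result.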